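Lengthening a Side Chain on a Shared Core

This account rests on a few compounds, and the source may have more. Where it says the series, first, only, none or still open, it means among the compounds named here.

Of the compounds shown here, three built on one core have been tested in a functional assay on the whole organism with Rattus norvegicus as the target; on this read-out higher numbers stand for an effect only at larger amounts of compound and lower numbers for an effect already at smaller amounts. Compound 1 `CCCCc1c(OC)nc2nc(C(=O)c3ccccc3)cn2c1CC` gives 10 mg/kg. Compound 2 `CCCCc1c(OC)nc2nc(C(=O)c3ccccc3)cn2c1C` gives 2 mg/kg, and compound 3 `CCc1c(OC)nc2nc(C(=O)c3ccccc3)cn2c1C` gives 2 mg/kg. One change, (methyl in place of hydrogen on a saturated chain carbon bound to an aromatic carbon), brought a 5.0-fold higher number from compound 2 to compound 1 (0.70 log units; beyond the scatter). Another change, (hydrogen in place of ethyl on a saturated chain carbon, two bonds along the chain from an aromatic carbon), gave no change at the digits printed from compound 2 to compound 3 (within the scatter), so the cores of compound 2 and compound 3 can be treated as equivalent on this read-out.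

Compound 4 `CCc1c(OC)nc2nc(C(=O)c3ccccc3)cn2c1CC` has not yet been measured. It differs from compound 3 by methyl in place of hydrogen on a saturated chain carbon bound to an aromatic carbon. This is the same change, at the same place, as the one that led from compound 2 to compound 1, and it occurs twice among these compounds. Among the measured compounds shown here, with the two cores behaving alike, that earlier step is the only guide available. The step from compound 3 to compound 4 in this assay is therefore expected to be a 5.0-fold higher number from compound 3 to compound 4 (0.70 log units; beyond the scatter), resting on a 5.0-fold higher number from compound 2 to compound 1 (0.70 log units; beyond the scatter). Compound 4 is estimated to give 10 mg/kg, most likely between 4 mg/kg and 25 mg/kg.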

Compound 4, minimum effective dose: 2 mg/kg
Compound 4: middle estimate off by 5.0-fold (0.70 log units), on the high side; measured number outside the range, below it.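

In this assay, methyl in place of hydrogen on a saturated chain carbon bound to an aromatic carbon gave no change at the digits printed from compound 3 to compound 4 (within the scatter), so this change did not carry over from the core of compound 2 to the core of compound 3: the same change on two cores in this assay, a 5.0-fold higher number (0.70 log units; beyond the scatter) from compound 2 to compound 1 and no change at the digits printed (within the scatter) from compound 3 to compound 4, 5.0-fold (0.70 log units) apart, beyond the scatter of two such steps Read the other way, hydrogen in place of ethyl on a saturated chain carbon, two bonds along the chain from an aromatic carbon, gave a 5.0-fold lower number from compound 1 to compound 4 (0.70 log units; beyond the scatter), so that change also depends on the core it is made on: the same change on two cores in this assay, no change at the digits printed (within the scatter) from compound 2 to compound 3 and a 5.0-fold lower number (0.70 log units; beyond the scatter) from compound 1 to compound 4, 5.0-fold (0.70 log units) apart, beyond the scatter of two such steps This shows that a step seen on one core cannot simply be transferred to the other in this series, but it does not show why, and these four compounds say nothing about any further core.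

The compounds shown leave open how a propyl group or a longer chain in place of the methyl would behave on either core. They also leave open what an amine at that same place would do.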